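Thioether in place of the propyl chain of compound 2

The source may report more compounds than this note shows. Statements on the series, on what has been measured and on what is new or still open speak of the compounds shown alone.

Measured so far in an ADME assay on microsomes from liver (Homo sapiens) for metabolic stability, read by LC-MS, tested at 0.5 uM; a higher number here means that the compound lasts longer, a lower number that the compound disappears faster:
compound 1 `Cc1nc(C)c([C@H](OC(C)(C)C)C(=O)O)c(N2CCC(C)(C)CC2)c1-c1ccc(OCCc2cc(F)c(F)cc2F)cc1` gives > 2 h, which is a limit of the assay.
compound 2 `Cc1nc(C)c([C@H](OC(C)(C)C)C(=O)O)c(N2CCC(C)(C)CC2)c1-c1ccc(CCCc2ccc(F)cc2)cc1` gives > 2 h, which is also a limit of the assay.

Compound 2 therefore stands at the top of what this assay reports, and the step that the two limits leave unreadable from compound 1 to compound 2 cannot be read as a number; both values sit at the limit of > 2 h in this assay, at which 2 of the 2 values shown sit, so nothing in the measured pair tells how large a change of the side chain on that aromatic carbon can be before the half-life falls into the readable range.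

The next compound, compound 3 `Cc1nc(C)c([C@H](OC(C)(C)C)C(=O)O)c(N2CCC(C)(C)CC2)c1-c1ccc(SCCc2ccc(F)cc2)cc1`, carries a sulfur-linked chain: (2-(4-fluorophenyl)ethyl)sulfanyl in place of 3-(4-fluorophenyl)propyl on an aromatic carbon. For the measured compounds named here, no measured step bears directly on this change; the only step available is unreadable, and the evidence is confined to two values at the limit.

Compound 3 is expected to stay near the limit, with an estimated half-life of 2.5 h (range 1 h to 6 h). The expected step that the limit leaves unreadable from compound 2 to compound 3 is therefore estimated as none beyond the scatter, with a fair chance that only a limit is reported again.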

Compound 3, half-life: > 2 h
Compound 3 ended at the assay's limit (the forecaster's own chance of this, stated with the estimate: 65%); the middle value is on the limit's open side.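

In this assay compound 3 gives > 2 h, a limit of the assay and not a number. The steps to compound 3 from compound 1 and compound 2 therefore cannot be read: the limit of > 2 h in this assay, at which 3 of the 3 values shown sit.

The compounds shown leave open the actual half-life of all three and which change on that aromatic carbon would bring it into the readable range.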